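Methylsulfanyl for methoxy in the series of compound 1

The source may hold more compounds than are shown below. What is called first, only, known or untested is meant among the compounds shown, and "the series" means these compounds.

Compound 1 `COc1ccc(CNc2nc([Se]C)nc3ccccc23)cc1` is the starting point of this step. In a functional assay on CCRF-CEM cells (Homo sapiens) for cytotoxicity, read by MTT assay, with a stated time of 72 h (on this read-out higher numbers stand for lower toxicity in this test and lower numbers for higher toxicity in this test), compound 1 gives > 100000 nM, which is a limit of the assay and not a number. Compound 2 `CSc1nc(NCCCCCO)c2cccnc2n1` belongs to the same set. In this assay compound 2 gives > 100000 nM, again a limit of the assay. Compound 3 `COc1ccc(CNc2nc(SC)nc3ccccc23)cc1` differs from compound 1 in one place on the core. In this assay compound 3 gives > 100000 nM, also a limit. Within the data shown here, the one measured step in this assay is a step that the two limits leave unreadable from compound 1 to compound 3, so its size cannot be read. The whole picture so far is the limit of > 100000 nM in this assay, at which 3 of the 3 values shown sit; no measured value in the set is a number.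

Compound 4 `CSc1ccc(CNc2nc([Se]C)nc3ccccc23)cc1` is not yet measured. It differs from compound 1 by methylsulfanyl in place of methoxy on an aromatic carbon. Among the measured compounds shown here, no measured step bears on this change directly, and the single measured step concerns a different position and is itself unreadable between two limits. With all three values sitting at the limit, the expectation for compound 4 in this assay is a further limit rather than a number. For compound 4 the expected step is a number no higher from compound 1 to compound 4 (the limit leaves the size open). The value for compound 4 in this assay is estimated at 100000 nM, within 20000 nM to 300000 nM.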

Compound 4, concentration lethal to 50% of the cells: > 100000 nM
Compound 4: a limit, no number; the forecaster's own chance of this, stated with the estimate: 85%; the middle value lies on the limit itself.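

In this assay, among these compounds, compound 1 and compound 4 both stand at a limit of the assay and not at a number, so no step between them can be read. The compounds shown leave open how methylsulfanyl compares with methoxy on an aromatic carbon, since all they offer is this: the limit of > 100000 nM in this assay, at which 4 of the 4 values shown sit.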